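A few compounds are considered here, and "the series" means these few. Any claim that something is new, unique, unknown or untested is made for them only; others in the source may bear on it.

Two related compounds have so far been measured in an ADME assay on Vero cells (Chlorocebus sabaeus) for cytotoxicity, read by MTT assay, with a stated time of 96 h; on this read-out lower numbers stand for higher toxicity in this test and higher numbers for lower toxicity in this test. In this test, compound 1 `COc1cc(NCc2ccc(C)o2)ccc1-c1cnco1`, which carries 5-methylfuran-2-yl on the saturated chain carbon bound to a nitrogen on an aromatic ring, gives 45200 nM. Compound 2 `COc1cc(NCc2cncs2)ccc1-c1cnco1`, which carries 1,3-thiazol-5-yl there instead, gives 232000 nM, the highest of the two numbers. Compound 3 `COc1cc(NCc2ccc(Br)s2)ccc1-c1cnco1` keeps the shared core and differs from compound 2 in a single place: 5-bromothiophen-2-yl in place of 1,3-thiazol-5-yl on a saturated chain carbon bound to a nitrogen on an aromatic ring. Within the data shown here, only one measured step bears on this change: a 5.1-fold higher number from compound 1 to compound 2 (0.71 log units; beyond the scatter). Among the measured compounds shown here, that step is modest, and it is the one step in which 1,3-thiazol-5-yl enters. In compound 3 this group leaves again, though 5-bromothiophen-2-yl is not the group of compound 1, so the earlier step offers only a loose guide. A lower number of similar size is therefore expected in this assay, although the direction rests on that one step. The estimate is a 3.9-fold lower number from compound 2 to compound 3 (0.59 log units; beyond the scatter), a step expected to lie beyond the scatter. Compound 3 is expected at 60000 nM, with an estimated range of 22000 nM to 150000 nM.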

Compound 3, half-maximal cytotoxic concentration: 47300 nM
Estimate against measurement, compound 3: 1.3-fold (0.10 log units) above; low and high end bracket the measured number.
By their numbers in this assay, from the lowest: compounds 1 and 3 (each within the scatter of the next); then compound 2.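

In this assay, a second group at this position, on a saturated chain carbon bound to a nitrogen on an aromatic ring, can now be set against 1,3-thiazol-5-yl: 5-bromothiophen-2-yl in its place gives a 4.9-fold lower number from compound 2 to compound 3 (0.69 log units; beyond the scatter) and so stands apart from it, as 5-methylfuran-2-yl did. The two groups other than 1,3-thiazol-5-yl are not separated by this read-out, since 5-bromothiophen-2-yl in place of 5-methylfuran-2-yl gives a 1.0-fold higher number from compound 1 to compound 3 (0.02 log units; within the scatter) and leaves both compounds within the scatter of each other. Among these three compounds, compound 2 alone stands apart from the others, and it is the only one carrying 1,3-thiazol-5-yl.

Nothing shown here gives a reason for this difference.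

The compounds shown leave open whether the higher number of compound 2 belongs to 1,3-thiazol-5-yl in particular or would recur with another ring on the same carbon, such as a pyridine or a plain phenyl. They also leave open what the bromine and the methyl contribute, which an unsubstituted thiophene or furan at this position would address.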